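A few compounds are considered here, and "the series" means these few. Any claim that something is new, unique, unknown or untested is made for them only; others in the source may bear on it.

In a functional assay on CCRF-CEM cells (Homo sapiens), with a stated time of 3 days (a lower number here means a stronger inhibitor, a higher number a weaker inhibitor), compound 1 `C=C1[C@H](O)[C@H](O)CO[C@@H]1n1ccc(O)nc1=O` gives > 800000 nM, which is a limit and not a number. Among the compounds with values here, compound 2 `O=C1C=CCO[C@@H]1n1ccc(O)nc1=O` gives 82000 nM, the only exact number so far. Compound 3 `O=C1C=CCO[C@@H]1n1cc(C(F)(F)F)c(O)nc1=O` differs from compound 2 in one place: trifluoromethyl in place of hydrogen on an aromatic carbon, with trifluoromethyl in place of hydrogen on an aromatic carbon. Within the data shown here, no measured pair shows what this kind of change does, so the expectation is tentative: a modest gain in potency, toward a lower number. The estimated step is a 2.7-fold lower number from compound 2 to compound 3 (0.44 log units; beyond the scatter). For compound 3, the expected value is 30000 nM, within an estimated range of 6000 nM to 150000 nM.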

Compound 3, half-maximal inhibitory concentration: 39000 nM
For compound 3 the middle estimate is 1.3-fold (0.11 log units) below the measured one, and the stated range covers the measured number.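

In this assay, trifluoromethyl in place of hydrogen on the aromatic carbon ortho to the hydroxy group gives a 2.1-fold lower number from compound 2 to compound 3 (0.32 log units; beyond the scatter) and so counts as a modest step. Within the data shown here, this single pair is the first measured sign that this carbon tolerates a group of 4 heavy atoms, and that the change here moves toward a stronger inhibitor. Nothing measured here accounts for the size of this step. On these data alone, whether an amine, a carboxylic acid or a longer chain on the same carbon would move the number in the same direction remains open.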